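A few compounds are considered here, and "the series" means these few. Any claim that something is new, unique, unknown or untested is made for them only; others in the source may bear on it.

Compound 1 `CO[C@@H]1C[C@@H]2[C@H]([C@]1(N)C(=O)O)[C@@]2(F)C(=O)O` is the parent of this pair: in an assay on CHO cells for binding affinity to metabotropic glutamate receptor 2 (Rattus norvegicus) (on this read-out higher numbers stand for weaker inhibition and lower numbers for stronger inhibition), compound 1 gives 39.2 nM, the highest of the two numbers recorded. Among the compounds with values here, the only neighbour is compound 2 `N[C@]1(C(=O)O)[C@H]2[C@@H](C[C@H]1OCCCc1ccccc1)[C@]2(F)C(=O)O`, which in this assay gives 9.83 nM; the step of a 4.0-fold lower number from compound 1 to compound 2 (0.60 log units; beyond the scatter) is the single measured change at the saturated chain carbon bound to an oxygen on a saturated carbon. Compound 3 `N#Cc1cccc(CO[C@@H]2C[C@@H]3[C@H]([C@]2(N)C(=O)O)[C@@]3(F)C(=O)O)c1` alters the same place: 3-cyanophenyl in place of hydrogen on a saturated chain carbon bound to an oxygen on a saturated carbon. The phenethyl step is the only one that bears on it, and it lowered the number beyond the scatter, so a step of similar direction and size is expected for the 3-cyanophenyl, with no measured ground to set it larger or smaller. Compound 3 is therefore expected to give 13 nM in this assay, with a range from 4 nM to 40 nM. The expected step is a 3.0-fold lower number from compound 1 to compound 3 (0.48 log units; beyond the scatter).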

Compound 3, inhibition constant: 2.94 nM
Compound 3: the middle estimate sits 4.4-fold (0.65 log units) above what was measured, outside the stated range (below it).
By their numbers in this assay, from the lowest: compound 3; then compound 2; then compound 1.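

In this assay, this place on the saturated chain carbon bound to an oxygen takes a second aromatic group with a lower number, and 3-cyanophenyl in place of hydrogen gives a 13-fold lower number from compound 1 to compound 3 (1.12 log units; beyond the scatter). The direct exchange of phenethyl for 3-cyanophenyl gives a 3.3-fold lower number from compound 2 to compound 3 (0.52 log units; beyond the scatter), so the number at this place depends on which group enters and not only on a group being present. No measurement here accounts for the difference between these two groups.

Phenethyl and 3-cyanophenyl differ in more than one feature, so the compounds shown cannot assign the lower number to the nitrile or to the ring and its link to the oxygen. A plain phenyl at this place would separate these, and a carboxylic acid or an amine in place of the nitrile would test whether that group matters.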